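The source may hold more compounds than are shown below. What is called first, only, known or untested is meant among the compounds shown, and "the series" means these compounds.

Measured in a functional assay on EOL1 cells (Homo sapiens) for inhibition, read by fluorescence, with a stated time of 72 h (on this read-out higher numbers stand for weaker inhibition of growth and lower numbers for stronger inhibition of growth), so far:
compound 1 `CCCCCCn1cnc2c(Nc3cc(OC)cc(OC)c3)nc(N[C@H]3CC[C@H](N)CC3)nc21` gives 380 nM
compound 2 `CCCCCCn1cnc2c(Nc3ccc(O)cc3)nc(N[C@H]3CC[C@H](N)CC3)nc21` gives 190 nM

For the measured compounds named here, the one measured step, a 2.0-fold lower number from compound 1 to compound 2 (0.30 log units; within the scatter), leaves compound 2 level with its only neighbour. Compound 3 `CC(C)CCn1cnc2c(Nc3ccc(O)cc3)nc(N[C@H]3CC[C@H](N)CC3)nc21` has isopropyl in place of butyl on a saturated chain carbon, two bonds along the chain from an aromatic nitrogen and otherwise matches compound 2. The measured step changed a different group, so no data bear directly on this chain, and no shift beyond the scatter is expected in this assay in either direction. The expected move is a 1.1-fold higher number from compound 2 to compound 3 (0.02 log units; within the scatter) and no more. Compound 3 is estimated at 200 nM with an expected range from 85 nM to 470 nM for now.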

Compound 3, concentration for 50% growth inhibition: 30 nM
Compound 3: middle estimate off by 6.7-fold (0.82 log units), on the high side; the whole stated range lies above it.
By their numbers in this assay, from the lowest: compound 3; then compounds 2 and 1 (each within the scatter of the next).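

In this assay, the hexyl to isopentyl change gives a 6.3-fold lower number from compound 2 to compound 3 (0.80 log units; beyond the scatter), so this chain matters to the read-out. For the compounds shown here, the only earlier step, at a different place, stayed within the scatter. Nothing available accounts for the gain.

With a single pair at this place, the effects of chain length and branching cannot be separated. A straight pentyl chain, a cyclopentyl ring or a chain ending in an amine would test this, as would isopentyl with the 3,5-dimethoxyphenyl group of compound 1.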